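This account rests on a few compounds, and the source may have more. Where it says the series, first, only, none or still open, it means among the compounds named here.

Measured in a functional assay on K562 cells (Homo sapiens) for antiproliferative activity, read by CellTiter-Glo, with a stated time of 72 h; a higher number here means that more compound is needed for the effect, a lower number that less compound is needed:
- compound 1 `CCCCCNc1ncnc2c1ncn2[C@@H]1O[C@H](COS(N)(=O)=O)[C@@H](O)[C@H]1O`: 181 nM
- compound 2 `CCCCCC(C)Nc1ncnc2c1ncn2[C@@H]1O[C@H](COS(N)(=O)=O)[C@@H](O)[C@H]1O`: 203 nM
- compound 3 `NS(=O)(=O)OC[C@H]1O[C@@H](n2cnc3c(NCC4CCCO4)ncnc32)[C@H](O)[C@@H]1O`: > 1000 nM (a limit, not a number)

Compound 3 is known only through this limit: the limit of > 1000 nM in this assay, at which 1 of the 3 values shown sits.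

The next compound, compound 4 `NS(=O)(=O)OC[C@H]1O[C@@H](n2cnc3c(NC4CCCCCCC4)ncnc32)[C@H](O)[C@@H]1O`, has cyclooctyl in place of (oxolan-2-yl)methyl on a nitrogen on an aromatic ring. Like pentyl and 1-methylhexyl, the entering group is carbon only.

The closest measured steps run towards compound 3: an at least 5.5-fold higher number from compound 1 to compound 3 (0.74 log units; beyond the scatter) and an at least 4.9-fold higher number from compound 2 to compound 3 (0.69 log units; beyond the scatter). Both are beyond the scatter, whereas a 1.1-fold higher number from compound 1 to compound 2 (0.05 log units; within the scatter) is within it. Within the data shown here, compound 4 is therefore expected to sit with compound 1 and compound 2 rather than with compound 3, although no measured compound carries cyclooctyl.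

A modest or larger move to a lower number is expected in this assay, estimated as an at least 5.0-fold lower number from compound 3 to compound 4 (0.69 log units; beyond the scatter). For compound 4 the estimated value is 200 nM, with an expected range of 70 nM to 650 nM.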

Compound 4, half-maximal effective concentration: 380 nM
Beside the measured number, compound 4's estimate is 1.9-fold (0.28 log units) below it; measured number inside the range.
By their numbers in this assay, from the lowest: compounds 1, 2 and 4 (each within the scatter of the next, the first and the last beyond it). At a limit, above all of these: compound 3.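

In this assay, a non-aromatic ring on a nitrogen on an aromatic ring does not by itself go with weak activity, as cyclooctyl shows: an at least 2.6-fold lower number from compound 3 to compound 4 (0.42 log units; beyond the scatter). Against the open chains, a 1.9-fold higher number from compound 2 to compound 4 (0.27 log units; within the scatter), and a 2.1-fold higher number from compound 1 to compound 4 (0.32 log units; beyond the scatter), so cyclooctyl stays level with 1-methylhexyl and only modestly apart from pentyl. Compound 3 stands only as a limit, so the step to compound 4 is a bound and not a measured size: the limit of > 1000 nM in this assay, at which 1 of the 4 values shown sits.

Still open, on these data alone, is whether the oxygen in (oxolan-2-yl)methyl or the smaller ring and its carbon link goes with that limit, and cyclopentylmethyl on the same nitrogen would separate the two. Also open, as far as these compounds go, is how a hydroxyl or an amine on the cyclooctyl ring would read here.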